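A few compounds are considered here, and "the series" means these few. Any claim that something is new, unique, unknown or untested is made for them only; others in the source may bear on it.

Measured so far in a functional assay on A549 cells (Homo sapiens) for cytotoxicity, read by MTT assay, with a stated time of 48 h; a higher number here means a weaker inhibitor, a lower number a stronger inhibitor:
- Compound 1 `CC(C)(C)c1ccc(/C=C/[C@](C)(O)CC[C@@H]2[C@@]3(C)CCCC(C)(C)[C@@H]3CC[C@@]2(C)O)cc1`: 45000 nM
- Compound 2 `CC1(C)CCC[C@]2(C)[C@@H](CC[C@@](C)(O)/C=C/c3ccc(F)cc3)[C@](C)(O)CC[C@@H]12`: 3100 nM

Compound 2, at 3100 nM, holds the lower of the two numbers in this assay. The next compound, compound 3 `CC1(C)CCC[C@]2(C)[C@@H](CC[C@@](C)(O)/C=C/c3ccc(Oc4ccccc4)cc3)[C@](C)(O)CC[C@@H]12`, has not yet been measured. It keeps the core of compound 2 and carries phenoxy in place of fluoro on an aromatic carbon. Among the compounds with values here, one measured step bears on this change: a 15-fold lower number from compound 1 to compound 2 (1.16 log units; beyond the scatter), a large step beyond the scatter, with fluoro in place of tert-butyl. Compound 3 again puts a group with more heavy atoms where compound 2 has fluoro, so a higher number is expected in this assay, though probably a more modest rise than that single step. Phenoxy itself is untested, so the uncertainty is wide. The expected change is a 3.9-fold higher number from compound 2 to compound 3 (0.59 log units; beyond the scatter). For compound 3 the estimated value is 12000 nM, with an expected range from 3000 nM to 50000 nM.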

Compound 3, half-maximal inhibitory concentration: 3200 nM
Estimate against measurement, compound 3: 3.8-fold (0.57 log units) above; measured number inside the range.
By their numbers in this assay, from the lowest: compounds 2 and 3 (each within the scatter of the next); then compound 1.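

In this assay, phenoxy in place of fluoro gives a 1.0-fold higher number from compound 2 to compound 3 (0.01 log units; within the scatter) and so leaves the number unmoved, which shows that this place on the aromatic ring accepts a group of 7 heavy atoms with a ring of its own as well as it accepts a single fluorine. Phenoxy in place of tert-butyl gives a 14-fold lower number from compound 1 to compound 3 (1.15 log units; beyond the scatter) as well, so the heavy-atom count of the group alone does not set the order of these three compounds: compound 1 stands apart, while compound 3, with the larger group of the two new comparisons, stays level with compound 2. Nothing measured here explains this difference between tert-butyl and phenoxy. The compounds shown leave open whether an amine or a carboxylic acid at this place would also leave the number unmoved. They also leave open whether the gap seen with tert-butyl recurs with isopropyl or a longer alkyl chain.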